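The compounds below may be only part of what the source reports. "The series", "measured", "known", "first", "only" and "open" are said of these compounds alone.

Measured compounds:
compound 1, `CCCCCc1c(C)nc(N)nc1NCCCC`, 1220 nM;
compound 2, `CCCC#Cc1c(C)nc(N)nc1NCCCC`, 5000 nM.

In an assay on HEK293 cells for agonist activity at Toll-like receptor 8 (Homo sapiens), read by spectrophotometry (on this read-out higher numbers stand for an effect only at larger amounts of compound and lower numbers for an effect already at smaller amounts), compound 2 gives the highest of the two numbers; the step of a 4.1-fold higher number from compound 1 to compound 2 (0.61 log units; beyond the scatter) is the only one measured. Compound 3, `CCCCNc1nc(N)nc(C)c1C#C[Si](C)(C)C`, differs from compound 2 by a group of 4 heavy atoms (3 carbon, 1 silicon; no ring) in place of a group of 3 heavy atoms (3 carbon; no ring), on a triple-bonded carbon. Among the compounds with values here, no measured step touches this position in this way, so the one step known gives no bearing on the direction. Compound 3 is therefore expected to sit near compound 2, with a 1.2-fold higher number from compound 2 to compound 3 (0.08 log units; within the scatter) and wide uncertainty. The estimate for compound 3 is 6000 nM, between 2000 nM and 20000 nM.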

Compound 3, half-maximal effective concentration: 9240 nM
Compound 3: the middle estimate sits 1.5-fold (0.19 log units) below what was measured, within the range that was stated.
By their numbers in this assay, from the lowest: compound 1; then compounds 2 and 3 (each within the scatter of the next).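

In this assay, a group of 4 heavy atoms containing silicon in place of propyl on the triple-bonded carbon gives a 1.8-fold higher number from compound 2 to compound 3 (0.27 log units; within the scatter), so at this position the exchange of carbon for silicon does not shift the number beyond the scatter. Against the pentyl of the saturated compound, the same group gives a 7.6-fold higher number from compound 1 to compound 3 (0.88 log units; beyond the scatter), which places both triple-bonded compounds at higher numbers than compound 1. No available evidence accounts for these numbers. The compounds shown leave open whether an amine, a hydroxyl group or a longer chain on the triple-bonded carbon would move the number beyond the scatter from compound 2.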